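The compounds below may be only part of what the source reports. "The series", "measured", "known", "first", "only" and "open" are said of these compounds alone.

compound 1 `CC1(C)[C@H]2CC[C@]1(C)N(Cc1cn(-c3cccc(C#N)c3)nn1)C(=O)C2` gives 230 nM
compound 2 `CC1(C)[C@H]2CC[C@]1(C)N(Cc1cn(-c3ccccc3O)nn1)C(=O)C2` gives 90 nM

Going by the values given here, compound 2 gives 90 nM in a functional assay on OVCAR-3 cells (Homo sapiens) for inhibition, read by MTT assay, with a stated time of 24 h (on this read-out higher numbers stand for weaker inhibition and lower numbers for stronger inhibition), and so holds the lower of the two numbers, with compound 1 as its only neighbour. Compound 3 `Cc1cccc(-n2cc(CN3C(=O)C[C@@H]4CC[C@@]3(C)C4(C)C)nn2)c1` has not yet been measured in this assay and differs from compound 2 in one place: 3-methylphenyl in place of 2-hydroxyphenyl on an aromatic nitrogen and the change is 3-methylphenyl in place of 2-hydroxyphenyl on an aromatic nitrogen. Among the compounds with values here, one measured step bears on this, namely a 2.6-fold lower number from compound 1 to compound 2 (0.41 log units; beyond the scatter) which is a modest move, made by 2-hydroxyphenyl replacing 3-cyanophenyl at that same place. Compound 3 also lacks the 2-hydroxyphenyl group, as compound 1 does with 230 nM so a return of similar size towards a higher number is expected. Within the data shown here, no measured compound carries 3-methylphenyl, and a single step is thin support, so the range is kept wide. The estimated change is a 2.1-fold higher number from compound 2 to compound 3 (0.32 log units; beyond the scatter) and it remains an expectation. For compound 3 the estimated value is 190 nM with an expected range from 80 nM to 450 nM.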

Compound 3, half-maximal inhibitory concentration: 160 nM
Beside the measured number, compound 3's estimate is 1.2-fold (0.07 log units) above it, and the stated range covers the measured number.
By their numbers in this assay, from the lowest: compounds 2, 3 and 1 (each within the scatter of the next, the first and the last beyond it).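

In this assay, putting 3-methylphenyl on the aromatic nitrogen in place of 2-hydroxyphenyl gives a 1.8-fold higher number from compound 2 to compound 3 (0.25 log units; within the scatter), so an exchange that leaves behind the hydrogen-bond donor and acceptor counted on the departing group yields no difference that this read-out can resolve. Methyl in place of cyano on an aromatic carbon gives a 1.4-fold lower number from compound 1 to compound 3 (0.16 log units; within the scatter), which also lies within the scatter. The earlier single step, a 2.6-fold lower number from compound 1 to compound 2 (0.41 log units; beyond the scatter), had suggested a clear separation between the two aryl groups at this position, but the new compound cannot be told apart from either of them, so this position now appears more tolerant of change than that step alone implied, at least across these three aryl groups.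

Nothing measured here speaks to what lies behind these numbers. Still open is whether an amine or a carboxylic acid on the same phenyl ring would give a number beyond the scatter from compound 3, and whether the hydroxyl group of compound 2 contributes anything on its own, since no pair shown changes that group alone while keeping its place on the ring.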